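Dimethoxymethyl to Ethyl: An Expected Antiproliferative Read-Out

The source may hold more compounds than are shown below. What is called first, only, known or untested is meant among the compounds shown, and "the series" means these compounds.

Two compounds with measured numbers open this account. Compound 1 `COC(CCn1cnc2c(NCc3ccc(C(=O)Nc4ccccc4N)cc3)nc(Cl)nc21)OC` and compound 2 `CC1CCN(c2nc(Cl)nc3c2ncn3Cc2ccc(/C=C/C(=O)Nc3ccccc3N)cc2)CC1` were each tested in a functional assay on HepG2 cells (Homo sapiens) for antiproliferative activity, read by CCK-8 assay, with a stated time of 72 h, tested at 8 uM; a lower number here means a weaker effect, a higher number a stronger effect of the compound at the concentration tested. In this assay compound 1 gives 34.2%, and compound 2 gives 32.2%. The two numbers sit within the usual scatter of each other, so neither compound can be called the stronger, and compound 1 stands simply as one of two closely matched results.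

Compound 3 `CCCCn1cnc2c(NCc3ccc(C(=O)Nc4ccccc4N)cc3)nc(Cl)nc21` has not yet been measured. It differs from compound 1 in one place: ethyl in place of dimethoxymethyl on a saturated chain carbon, two bonds along the chain from an aromatic nitrogen. For the measured compounds named here, no measured pair in this set isolates this change, so the expectation rests on the two numbers alone. The step of a number 4.2 percentage points lower from compound 1 to compound 3 (within the scatter) is expected to be small and, if anything, slightly downward, not clearly beyond the scatter. Compound 3 is therefore expected to give about 30% in this assay, within a range from 15% to 45%.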

Compound 3, a percentage reported as inhibition, at one concentration (the size of the read-out at that concentration, not a potency): 19.6%
Compound 3: middle estimate off by 10.4 percentage points, on the high side; the measured number falls inside the stated range.
By their numbers in this assay, from the lowest: compound 3; then compounds 2 and 1 (each within the scatter of the next).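

In this assay the change from dimethoxymethyl to ethyl gives a number 14.6 percentage points lower from compound 1 to compound 3 (beyond the scatter), so this position on the chain is not indifferent to the group it carries. With the rest of the structure held the same, the pair shows that the read-out depends on what sits at the chain end, and that the dimethoxymethyl compound keeps the higher number. The data offer no measurement that accounts for this step.

The compounds shown leave open how the chain would read with a different end, such as a single methoxy group, an amine or a carboxylic acid, or as a longer chain such as pentyl. They also leave open whether this step would hold at other concentrations, since this single pair rests on one tested concentration.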